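Urea side-chain variation on a quinazoline antiproliferative series

The source may report more compounds than this note shows. Statements on the series, on what has been measured and on what is new or still open speak of the compounds shown alone.

Compound 1 `COCCNC(=O)Nc1cc2c(Nc3ccc(F)c(Cl)c3)ncnc2cc1O[C@H]1CCOC1` — 387 nM
Compound 2 `COCCCNC(=O)Nc1cc2c(Nc3ccc(F)c(Cl)c3)ncnc2cc1O[C@H]1CCOC1` — 4100 nM
Compound 3 `COC(CCNC(=O)Nc1cc2c(Nc3ccc(F)c(Cl)c3)ncnc2cc1O[C@H]1CCOC1)OC` — 22000 nM

In a functional assay on A-431 cells (Homo sapiens) for antiproliferative activity, read by sulforhodamine B assay, with a stated time of 72 h (a higher number here means a weaker inhibitor, a lower number a stronger inhibitor), compound 3 stands as the highest of the three numbers, set apart from compound 2 by a 5.4-fold higher number from compound 2 to compound 3 (0.73 log units; beyond the scatter) and from compound 1 by a 57-fold higher number from compound 1 to compound 3 (1.75 log units; beyond the scatter). Compound 4 `O=C(Nc1cc2c(Nc3ccc(F)c(Cl)c3)ncnc2cc1O[C@H]1CCOC1)N1CCC(F)CC1` differs from compound 3 by 4-fluoropiperidin-1-yl in place of (3,3-dimethoxypropyl)amino on a carbonyl carbon. No measured step covers such an exchange; the shown steps, an 11-fold higher number from compound 1 to compound 2 (1.03 log units; beyond the scatter) and a 57-fold higher number from compound 1 to compound 3 (1.75 log units; beyond the scatter), only describe growth of the open chain. The shorter chain of compound 1 gives the lowest number, so a compact replacement is expected to lower the number, with wide uncertainty: the step from compound 3 to compound 4 is estimated at an 11-fold lower number from compound 3 to compound 4 (1.04 log units; beyond the scatter). Compound 4 is expected to give 2000 nM, between 300 nM and 15000 nM.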

Compound 4, half-maximal inhibitory concentration: 3040 nM
The estimate for compound 4 lay 1.5-fold (0.18 log units) below the measured number; low and high end bracket the measured number.
By their numbers in this assay, from the lowest: compound 1; then compounds 4 and 2 (each within the scatter of the next); then compound 3.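

On the carbonyl carbon, a ring with no hydrogen-bond donor proves compatible with activity in this assay, and the open chains no longer define the range: 4-fluoropiperidin-1-yl gives a 7.2-fold lower number from compound 3 to compound 4 (0.86 log units; beyond the scatter) against (3,3-dimethoxypropyl)amino. Against (3-methoxypropyl)amino it gives a 1.3-fold lower number from compound 2 to compound 4 (0.13 log units; within the scatter) and so stands level, while against (2-methoxyethyl)amino it gives a 7.9-fold higher number from compound 1 to compound 4 (0.90 log units; beyond the scatter) and does not match that short chain. No measurement here bears on the reason for these differences. The compounds shown do not separate the contribution of the ring from that of the fluorine, and they leave open how unsubstituted piperidin-1-yl or morpholin-4-yl would fare on this carbonyl carbon.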